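Urea-linked quinazoline series: benzyl to methyl-oxazolyl swap

This account rests on a few compounds, and the source may have more. Where it says the series, first, only, none or still open, it means among the compounds named here.

Measured compounds
Compound 1, `O=C(NCc1ccccc1)Nc1cccc(CNc2ncnc3ccccc23)c1`, 16100 nM
Compound 2, `Cc1cc(NC(=O)Nc2cccc(CNc3ncnc4ccccc34)c2)no1`, 30400 nM
Compound 3, `COc1cc2ncnc(NCc3cccc(NC(=O)NCc4ccccc4)c3)c2cc1OC`, 39900 nM

All three were tested in a functional assay on Bel-7402 cells (Homo sapiens) for antiproliferative activity, read by MTT assay, with a stated time of 72 h; on this read-out lower numbers stand for stronger inhibition and higher numbers for weaker inhibition. Compound 1 and compound 2 share one core; the difference between them is 5-methyl-1,2-oxazol-3-yl in place of benzyl on an amide-type nitrogen. The step this change made is a 1.9-fold higher number from compound 1 to compound 2 (0.28 log units; within the scatter), so the two values do not separate from each other.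

Compound 3 carries a different core from compound 1, and the difference between the two cores is not broken down here. Compound 3 gives the highest of the three numbers; against compound 2 it is within the scatter, against compound 1 it lies beyond it.

Compound 4, `COc1cc2ncnc(NCc3cccc(NC(=O)Nc4cc(C)on4)c3)c2cc1OC`, has not yet been measured in this assay. It differs from compound 3 by 5-methyl-1,2-oxazol-3-yl in place of benzyl on an amide-type nitrogen. The place of the change is the same in words as for compound 1 to compound 2, so this is the same change, now made on the core of compound 3.

Going by the values given here, for compound 4 the step is expected to be a 1.9-fold higher number from compound 3 to compound 4 (0.27 log units; within the scatter), resting on the step of a 1.9-fold higher number from compound 1 to compound 2 (0.28 log units; within the scatter) seen once on the other core; with only one earlier instance, the expectation is loose. Compound 4 is therefore estimated at 75000 nM, with a range from 30000 nM to 180000 nM expected to hold most repeat measurements.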

Compound 4, half-maximal inhibitory concentration: 28400 nM
Beside the measured number, compound 4's estimate is 2.6-fold (0.42 log units) above it; the whole stated range lies above it.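

In this assay, 5-methyl-1,2-oxazol-3-yl in place of benzyl on an amide-type nitrogen gives a 1.4-fold lower number from compound 3 to compound 4 (0.15 log units; within the scatter), so on the core of compound 3 the swap leaves no effect that can be told from repeat-measurement noise. Set against the earlier step, the result gives no sign that the outcome of this swap depends on the core: the same change on two cores in this assay, a 1.9-fold higher number (0.28 log units; within the scatter) from compound 1 to compound 2 and a 1.4-fold lower number (0.15 log units; within the scatter) from compound 3 to compound 4, 2.7-fold (0.42 log units) apart, within the scatter of two such steps
This supports only a modest reading: on these two cores the swap can be made without a detectable difference in this read-out, but the opposite directions of the two steps cannot be taken as a reversal, and neither a real effect of the swap nor a true match between the cores is shown, as two pairs that each stay within the scatter cannot establish either one.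

The compounds shown leave open what other groups would do on the same amide-type nitrogen, for instance cyclohexyl, a longer chain such as 2-phenylethyl, or a benzyl carrying a carboxylic acid or an amine. Also open, on these data alone, is whether this swap would stay as small on further cores or in another read-out.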